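The compounds below may be only part of what the source reports. "The series", "measured", "known", "first", "only" and "open" are said of these compounds alone.

Measured compounds:
Compound 1 `Cc1cc(O)cc(-c2nn(CC#N)cc2-c2ccnc(-c3ccc(Oc4ccccc4)cc3)c2)c1` — -83%
Compound 2 `COc1cc(C)cc(-c2nn(CC#N)cc2-c2ccnc(-c3ccc(N(C)C)cc3)c2)c1` — 15%

In a functional assay on OVCAR-4 cells (Homo sapiens) for cytotoxicity, read by sulforhodamine B assay, with a stated time of 48 h, tested at 10 uM (a lower number here means a stronger effect, a higher number a weaker effect of the compound at the concentration tested), compound 1 gives -83%, while compound 2 gives 15%. Of the two numbers shown, compound 2 stands highest, its nearest neighbour being compound 1, whose number is lower by a gap that lies beyond the scatter. Compound 3 `Cc1cc(O)cc(-c2nn(CC#N)cc2-c2ccnc(-c3ccc(N(C)C)cc3)c2)c1` has not yet been measured. It differs from compound 2 in one place: hydrogen in place of methyl on an oxygen on an aromatic ring. Going by the values given here, no step between two measured compounds isolates this change, so its size in this assay is not known from the data; the pair of compound 1 and compound 2 differs in two places at once and shows only their combined outcome. Compound 3 is expected to move downward by a number 30 percentage points lower from compound 2 to compound 3 (beyond the scatter), a step that may exceed the scatter, with wide uncertainty. The estimate for compound 3 is -15%, in a range from -75% to 30%.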

Compound 3, a percentage reported as activity, at one concentration (the size of the read-out at that concentration, not a potency): 9%
Beside the measured number, compound 3's estimate is 24 percentage points below it; the measured number falls inside the stated range.
By their numbers in this assay, from the lowest: compound 1; then compounds 3 and 2 (each within the scatter of the next).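

In this assay, hydrogen in place of methyl on the oxygen, which turns the 3-methoxy-5-methylphenyl group into 3-hydroxy-5-methylphenyl, gives a number 6 percentage points lower from compound 2 to compound 3 (within the scatter), so with dimethylamino in the other place, methoxy and hydroxy cannot be told apart here. The other change, dimethylamino in place of phenoxy on an aromatic carbon, gives a number 92 percentage points higher from compound 1 to compound 3 (beyond the scatter), which isolates a large effect that the earlier pair showed only combined with the change on the oxygen. No measured evidence accounts for either step.

From the compounds shown here alone, whether methoxy and hydroxy also cannot be told apart when phenoxy stands in the other place remains open. Also open, going by these compounds, is how an ethoxy group or an amine in place of the hydroxy would read, and how a smaller group such as methoxy would read in place of phenoxy.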